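This account rests on a few compounds, and the source may have more. Where it says the series, first, only, none or still open, it means among the compounds named here.

In a functional assay on HepG2 cells (Homo sapiens) for cytotoxicity, read by MTT assay, with a stated time of 48 h (on this read-out higher numbers stand for weaker inhibition and lower numbers for stronger inhibition), compound 2 `COc1ccc2nc(Cl)c(Cn3cc(CN4c5ccccc5C(C)=CC4(C)C)nn3)cc2c1` gives 41200 nM, which lies within the scatter of compound 1 `COc1ccc2c(c1)C(C)=CC(C)(C)N2Cc1cn(Cc2cc3cc(OC)ccc3nc2Cl)nn1` at 27200 nM and apart from compound 3 `CC1=CC(C)(C)N(Cc2cn(Cc3cc4ccccc4nc3Cl)nn2)c2ccccc21` at 13100 nM. Compound 4 `COc1ccc2nc(Cl)c(Cn3cc(CN4c5ccc(C)cc5C(C)=CC4(C)C)nn3)cc2c1` differs from compound 2 by methyl in place of hydrogen on an aromatic carbon. For the measured compounds named here, no measured step adds a methyl. The nearest guides are two replacements of methoxy by hydrogen on an aromatic carbon, a 1.5-fold higher number from compound 1 to compound 2 (0.18 log units; within the scatter) and a 3.1-fold lower number from compound 2 to compound 3 (0.50 log units; beyond the scatter). Neither step is a direct precedent, so only a small shift is expected. In this assay the expected step is a 1.2-fold lower number from compound 2 to compound 4 (0.10 log units; within the scatter), toward a lower number and not beyond the scatter. For compound 4 the estimated value is 33000 nM, with an expected range from 17000 nM to 62000 nM.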

Compound 4, half-maximal inhibitory concentration: 21600 nM
Compound 4: the middle estimate sits 1.5-fold (0.18 log units) above what was measured, within the range that was stated.
By their numbers in this assay, from the lowest: compounds 3, 4, 1 and 2 (each within the scatter of the next, the first and the last beyond it).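

In this assay, the change at this aromatic carbon gives a 1.9-fold lower number from compound 2 to compound 4 (0.28 log units; within the scatter) and, with methyl in place of methoxy at the same carbon, a 1.3-fold lower number from compound 1 to compound 4 (0.10 log units; within the scatter). Hydrogen, methoxy and methyl at this carbon therefore give values within the scatter of one another, on the methoxy-bearing side of the shared core. Nothing available explains these small steps. 

On these data alone, it remains open whether an amine or a carboxylic acid at this carbon would give a step beyond the scatter. As far as these compounds go, whether methyl gives a similar step on the core of compound 3 is also open.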